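Swapping the aryl group on compound 2: expected stability

This account rests on a few compounds, and the source may have more. Where it says the series, first, only, none or still open, it means among the compounds named here.

In an ADME assay (liver) for metabolic stability, with Liver microsome (Homo sapiens) as the target, using microsomes, with a stated time of 0.5 h, tested at 1 uM (a higher number here means that more of the compound is left, a lower number that less of the compound is left), compound 1 `C[C@H](c1ccccc1)N1C(=O)O[C@](Cc2ccccc2)(c2nnc(-c3ccccc3)[nH]2)C1=O` gives 78%.
In this assay compound 2 `C[C@H](c1ccccc1)N1C(=O)O[C@](Cc2ccccc2)(c2nnc(-c3ccc(Cl)c(Cl)c3)[nH]2)C1=O` gives 88%.

Among the measured compounds shown here, compound 2 carries the higher of the two numbers, but the only measured step, a number 10 percentage points higher from compound 1 to compound 2 (within the scatter), lies within the scatter, so the two compounds are not distinguished. Compound 3 `COc1cc(OC)cc(-c2nnc([C@@]3(Cc4ccccc4)OC(=O)N([C@H](C)c4ccccc4)C3=O)[nH]2)c1` differs from compound 2 by 3,5-dimethoxyphenyl in place of 3,4-dichlorophenyl on an aromatic carbon. That step from compound 1 to compound 2 is the only one bearing on this position and was within the scatter, so no step beyond the scatter is expected for compound 3. Compound 3 is therefore estimated at 80%, between 60% and 95%, an expected step of a number 8 percentage points lower from compound 2 to compound 3 (within the scatter).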

Compound 3, percent of the compound remaining: 74%
Beside the measured number, compound 3's estimate is 6 percentage points above it; the range from low to high includes it.
By their numbers in this assay, from the lowest: compounds 3, 1 and 2 (each within the scatter of the next, the first and the last beyond it).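

Among the compounds shown here, the step of a number 14 percentage points lower from compound 2 to compound 3 (beyond the scatter) is the first at this position to lie beyond the scatter, so the choice of aryl group on the shared core can register in this assay after all. Yet a number 4 percentage points lower from compound 1 to compound 3 (within the scatter) leaves 3,5-dimethoxyphenyl unseparated from phenyl, so only the two substituted aryl groups stand apart. No evidence is at hand to explain this difference. The compounds shown leave open whether the step follows the chlorine atoms, the methoxy groups or their placing on the ring, and how an amine or a carboxylic acid on that ring would fare.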